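Swapping Fluoro for Methyl on a Weak Inhibitor

The compounds below may be only part of what the source reports. "The series", "measured", "known", "first", "only" and "open" are said of these compounds alone.

Compound 1, `Fc1ccc(Cn2cc(CSC(=S)N3CCNCC3)nn2)cc1`, was tested in a functional assay on ECa-109 cells (Homo sapiens) for inhibition, read by MTT assay, with a stated time of 72 h; a lower number here means a stronger inhibitor, a higher number a weaker inhibitor. There compound 1 gives > 128000 nM, which is a limit of the assay rather than a measured number. Its companion, compound 2, `O=C(OCc1ccccc1)N1CCN(C(=S)SCc2cn(Cc3ccc(F)cc3)nn2)CC1`, carries a benzyloxycarbonyl group on the ring amine nitrogen, and in this assay compound 2 gives 32000 nM. Within the data shown here, the step of an at least 4.0-fold lower number from compound 1 to compound 2 (0.60 log units; beyond the scatter) is the only measured change, and it rests on (the limit of > 128000 nM in this assay, at which 1 of the 2 values shown sits), so its true size stays open.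

Compound 3, `Cc1ccc(Cn2cc(CSC(=S)N3CCNCC3)nn2)cc1`, differs from compound 1 in another way: methyl in place of fluoro on an aromatic carbon. Neither the step from compound 1 to compound 2 nor any other measured step touches this part of the molecule, so there is no measured guide to how large a step to expect in this assay, nor in which direction. Compound 1 already sits at the limit of > 128000 nM in this assay, at which 1 of the 2 values shown sits, which leaves little room for a worse number to show. Compound 3 is therefore expected to stay near that limit, estimated at 150000 nM, within a range from 40000 nM to 600000 nM. That expectation amounts to a step that the limit leaves unreadable from compound 1 to compound 3.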

Compound 3, half-maximal inhibitory concentration: > 128000 nM
Compound 3: only a limit was reported; the forecaster's own chance of this, stated with the estimate: 60%; the middle value does not contradict the limit.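

In this assay compound 3 gives > 128000 nM, which is a limit of the assay and not a number. Compound 1 also stands at a limit, so no step between compound 1 and compound 3 can be read: the limit of > 128000 nM in this assay, at which 2 of the 3 values shown sit.

The compounds shown leave open whether 4-fluorophenyl and 4-methylphenyl differ at all in this measurement.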